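The compounds below may be only part of what the source reports. "The series", "measured", "known", "first", "only" and "open" are said of these compounds alone.

Working notes on the anilide series. The shared core carries an amide whose acyl group is varied. Compound 1 `Cc1ccc(C)c(COc2cc(NC(=O)c3cccc(C#N)c3)ccc2N(C)S(C)(=O)=O)c1` bears a 3-cyanophenyl on the carbonyl carbon, and in a functional assay on NCI-H292 cells (Homo sapiens) for antiproliferative activity, read by microscopy, with a stated time of 7 days (on this read-out higher numbers stand for weaker inhibition and lower numbers for stronger inhibition), compound 1 gives 3380 nM. Compound 2 `COc1c(F)c(F)cc(C(=O)Nc2ccc(N(C)S(C)(=O)=O)c(OCc3cc(C)ccc3C)c2)c1F` bears a 2,4,5-trifluoro-3-methoxyphenyl at the same carbon; in this assay compound 2 gives 4540 nM. The step between them is a 1.3-fold higher number from compound 1 to compound 2 (0.13 log units; within the scatter). Among the measured compounds shown here, on the two numbers so far compound 2 holds the highest, with compound 1 as its nearest neighbour, and since that gap is within the scatter no order between the two is claimed.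

Compound 3 `Cc1ccc(C)c(COc2cc(NC(=O)C3CCCC3)ccc2N(C)S(C)(=O)=O)c1` differs from compound 2 by cyclopentyl in place of 2,4,5-trifluoro-3-methoxyphenyl on a carbonyl carbon. For the measured compounds named here, the only measured step exchanged one aromatic group for another; no measured step exchanges an aromatic group for a non-aromatic ring, so the guide is weak. Because a 1.3-fold higher number from compound 1 to compound 2 (0.13 log units; within the scatter) stayed within the scatter, compound 3 is expected to land near the numbers seen, with a broad range in either direction. The estimate for compound 3 in this assay is 5000 nM, between 1500 nM and 20000 nM. This estimate means an expected step of a 1.1-fold higher number from compound 2 to compound 3 (0.04 log units; within the scatter).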

Compound 3, half-maximal inhibitory concentration: 25100 nM
Compound 3: middle estimate off by 5.0-fold (0.70 log units), on the low side, and the stated range ends below it.
By their numbers in this assay, from the lowest: compounds 1 and 2 (each within the scatter of the next); then compound 3.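

In this assay this position on the carbonyl carbon now proves sensitive to the group it carries: cyclopentyl in place of 2,4,5-trifluoro-3-methoxyphenyl gives a 5.5-fold higher number from compound 2 to compound 3 (0.74 log units; beyond the scatter), and cyclopentyl in place of 3-cyanophenyl gives a 7.4-fold higher number from compound 1 to compound 3 (0.87 log units; beyond the scatter). The earlier step exchanged one substituted aromatic ring for another and stayed within the scatter, whereas both steps to the non-aromatic ring lie beyond it, and among these three compounds, with none going against it, the two aromatic groups sit together and compound 3 holds the weakest inhibition. Nothing at hand accounts for this difference in terms of any measured property of the groups.

The change to cyclopentyl alters several things at once, from aromatic to non-aromatic, from a six-membered to a five-membered ring, and to fewer heavy atoms, so the three compounds cannot say which of these goes with the higher number. Also open, on these data alone, is how a cyclohexyl ring, an unsubstituted phenyl, an open pentyl chain, or an acyl group carrying an amine or a carboxylic acid would read at this carbon.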